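This account rests on a few compounds, and the source may have more. Where it says the series, first, only, none or still open, it means among the compounds named here.

Two compounds of a shared core carry measurements in a functional assay on HCT-116 cells (Homo sapiens) for cytotoxicity, read by MTT assay, with a stated time of 48 h; a lower number here means a stronger inhibitor, a higher number a weaker inhibitor. Compound 1, `O=c1ccc2cc(OCc3cc(-c4ccc5ccccc5c4)no3)ccc2o1`, gives 55900 nM in this assay. Compound 2, `COc1ccc(-n2cc(COc3ccc4oc(=O)ccc4c3)nn2)cc1`, gives 37800 nM in this assay. These two numbers sit within the usual scatter of each other, so neither can be called the stronger inhibitor on this evidence; both point to weak cytotoxicity.

Compound 3, `O=c1ccc2cc(OCc3cn(-c4ccc([N+](=O)[O-])cc4)nn3)ccc2o1`, has not yet been measured. It differs from compound 2 in one place: nitro in place of methoxy on an aromatic carbon. Among the compounds with values here, no pair of measured compounds shows what such a change does, so there is nothing to build a direction on. The expectation is therefore a step from compound 2 to compound 3 of about a 1.1-fold lower number from compound 2 to compound 3 (0.03 log units; within the scatter), no larger than the scatter. On that basis compound 3 is estimated at 35000 nM in this assay, with a plausible range from 15000 nM to 80000 nM.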

Compound 3, half-maximal inhibitory concentration: 44300 nM
Compound 3: the middle estimate sits 1.3-fold (0.10 log units) below what was measured; measured number inside the range.
By their numbers in this assay, from the lowest: compounds 2, 3 and 1 (each within the scatter of the next).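

In this assay, putting nitro in place of methoxy on the aromatic carbon para to a large group gives a 1.2-fold higher number from compound 2 to compound 3 (0.07 log units; within the scatter) and so leaves no readable mark on the result. Within the data shown here, this is the first direct look at this position, and it shows that 4-methoxyphenyl and 4-nitrophenyl cannot be told apart here, even though the two groups differ in their atoms and in their hydrogen-bond acceptors. No measurement at hand explains this outcome.

Still open, as far as these compounds go, is whether a group of another kind at this place, such as an amine or a carboxylic acid, would shift the number beyond the scatter. Also open, from the compounds shown here alone, is whether a bare phenyl ring, with no group there at all, would read any differently from compound 2 and compound 3.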